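A methoxy added to the anilino ring of compound 1

A few compounds are considered here, and "the series" means these few. Any claim that something is new, unique, unknown or untested is made for them only; others in the source may bear on it.

Measured compounds:
compound 1 `Cc1nc(SCC(=O)Nc2nc(-c3ccc(Cl)cc3)cs2)n(Nc2ccccc2)c1C` — 4800 nM
compound 2 `Cc1ccc(Nn2c(SCC(=O)Nc3nc(-c4ccccc4)cs3)nc(C)c2C)cc1` — 9100 nM

In a functional assay on SF-268 cells (Homo sapiens) for antiproliferative activity, read by sulforhodamine B assay, with a stated time of 48 h (on this read-out higher numbers stand for weaker inhibition of growth and lower numbers for stronger inhibition of growth), compound 1 gives 4800 nM, the smaller of the two numbers, but compound 2 at 9100 nM lies within the scatter of it, so the two cannot be told apart. Compound 3 `COc1ccc(Nn2c(SCC(=O)Nc3nc(-c4ccc(Cl)cc4)cs3)nc(C)c2C)cc1` differs from compound 1 by methoxy in place of hydrogen on an aromatic carbon. Among the measured compounds shown here, no measured pair shows this change, so its size is unknown. Compound 3 is expected to give 4500 nM, within a range from 1500 nM to 14000 nM. The estimated step of a 1.1-fold lower number from compound 1 to compound 3 (0.03 log units; within the scatter) is expected to be none beyond the scatter.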

Compound 3, concentration for 50% growth inhibition: 2810 nM
Estimate against measurement, compound 3: 1.6-fold (0.20 log units) above; measured number inside the range.
By their numbers in this assay, from the lowest: compounds 3, 1 and 2 (each within the scatter of the next, the first and the last beyond it).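

In this assay, methoxy in place of hydrogen on the anilino ring, para to a large group, gives a 1.7-fold lower number from compound 1 to compound 3 (0.23 log units; within the scatter) and so leaves the number indistinguishable from that of compound 1. Among the compounds shown here, this is the first reading at this position, and it shows that the added methoxy is tolerated there without a change that can be told from the scatter. Nothing available bears on why the number stays put.

On these data alone, it remains open whether an amine, a carboxylic acid or a longer chain such as ethoxy at this place would move the number beyond the scatter.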